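Swapping trifluoromethyl for a single fluorine on the aryl ring

This account rests on a few compounds, and the source may have more. Where it says the series, first, only, none or still open, it means among the compounds named here.

Of the compounds shown here, three built on one shared core have been tested in an assay on HEK293 cells for inhibition of Voltage-dependent T-type calcium channel subunit alpha-1G (Homo sapiens), read by fluorescence, tested at 10 uM; a higher number here means more inhibition at the concentration tested (going by the name of the read-out), a lower number less inhibition. Compound 1 `CCCc1nc(-c2ccccc2)c(CNCCN2CCN(c3cccc(C(F)(F)F)c3)CC2)o1` gives 56.3%. Compound 2 `CCCc1nc(-c2ccccc2)c(CNCCN2CCN(c3cccc(OC)c3)CC2)o1` gives 40.2%. Compound 3 `CCCc1nc(-c2ccccc2)c(CNCCN2CCN(c3ccc(C(F)(F)F)cc3)CC2)o1` gives 58.7%, the highest of the three numbers; its gap to compound 1 lies within the scatter, while its gap to compound 2 lies beyond it.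

Compound 4 `CCCc1nc(-c2ccccc2)c(CNCCN2CCN(c3cccc(F)c3)CC2)o1` differs from compound 3 in one place: 3-fluorophenyl in place of 4-(trifluoromethyl)phenyl on an amine nitrogen in a ring.

Within the data shown here, two measured steps bear on this change. Putting methoxy in place of trifluoromethyl on the aromatic carbon gave a number 16.1 percentage points lower from compound 1 to compound 2 (beyond the scatter), whereas moving the trifluoromethyl group to the other ring position gave a number 2.4 percentage points higher from compound 1 to compound 3 (within the scatter), so the position alone mattered little. The step of a number 18.5 percentage points higher from compound 2 to compound 3 (beyond the scatter) combines both changes. Here the entering group keeps one fluorine but drops the trifluoromethyl group, a smaller change than the swap to methoxy, so a modest decrease is expected, likely near the edge of the scatter.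

Compound 4 is therefore estimated to give about 47%, with a range from 32% to 62%. The expected step is a number 11.7 percentage points lower from compound 3 to compound 4 (beyond the scatter).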

Compound 4, a percentage reported as inhibition, at one concentration (the size of the read-out at that concentration, not a potency): 62.3%
Beside the measured number, compound 4's estimate is 15.3 percentage points below it; measured number above the stated range.
By their numbers in this assay, from the lowest: compound 2; then compounds 1, 3 and 4 (each within the scatter of the next).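

Fluoro in place of trifluoromethyl gave a number 6 percentage points higher from compound 1 to compound 4 (within the scatter), and 3-fluorophenyl in place of 4-(trifluoromethyl)phenyl gave a number 3.6 percentage points higher from compound 3 to compound 4 (within the scatter), so in this assay the trifluoromethyl group is not required to reach this level of inhibition, even though the entering 3-fluorophenyl has fewer heavy atoms than the group it replaces. Methoxy is the one group that stands apart among those shown: fluoro in place of methoxy gave a number 22.1 percentage points higher from compound 2 to compound 4 (beyond the scatter), which ties the lower number of compound 2 to methoxy itself rather than to the loss of trifluoromethyl. There is no supporting measurement here that could explain why fluoro and trifluoromethyl read alike while methoxy does not.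

The compounds shown leave open whether this aryl ring needs any substituent at all, and whether a chloro or a methyl group would read like fluoro and trifluoromethyl or like methoxy, with a plain phenyl ring as the simplest comparison. Fluorine appears only in the 3-fluorophenyl group, so how much its ring position matters also remains unknown.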